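The compounds below may be only part of what the source reports. "The series", "measured", "known", "first", "only" and "open" are said of these compounds alone.

Measured compounds:
Compound 1, `CCN(CC)c1c(C)n(CC)c(=O)n(-c2ccccc2)c1=O`, which in a physicochemical assay for lipophilicity (on this read-out lower numbers stand for lower lipophilicity and higher numbers for higher lipophilicity), gives 2.2.
Compound 2, `CCN(CC)c1c(C)n(C)c(=O)n(-c2ccccc2)c1=O`, which in this assay gives 2.11.
Compound 3, `CCN(CC)c1c(C)n(-c2ccccc2)c(=O)n(C)c1=O`, which in this assay gives 2.19.

Compound 2 and compound 1 differ in one place: methyl in place of hydrogen on a saturated chain carbon bound to an aromatic nitrogen. The step this made in this assay is a number 0.09 log units higher from compound 2 to compound 1 (within the scatter), so the two numbers are not told apart by this read-out.

Compound 3 carries the same atoms as compound 2 joined in a different way; the difference between the two cores is not broken down here. Compound 3 and compound 2 give numbers within the scatter of each other, and so do compound 3 and compound 1.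

Compound 4, `CCN(CC)c1c(C)n(-c2ccccc2)c(=O)n(CC)c1=O`, has not yet been measured. It differs from compound 3 in one place: methyl in place of hydrogen on a saturated chain carbon bound to an aromatic nitrogen. The place is described in the same words as for the change from compound 2 to compound 1, so this is the same change, carried out on a core that is itself not broken down against the other. Among the measured compounds shown here, because the only measured example of this change gave a number 0.09 log units higher from compound 2 to compound 1 (within the scatter), the step expected from compound 3 to compound 4 is small, a number 0.09 log units higher from compound 3 to compound 4 (within the scatter), and the expectation rests on that single pair alone. For compound 4 the estimated value in this assay is 2.28, expected to lie between 2 and 2.55.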

Compound 4, partition coefficient: 2.78
Beside the measured number, compound 4's estimate is 0.50 log units below it; the measured number lies above the stated range.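

In this assay, among the compounds shown here, the change of methyl in place of hydrogen on a saturated chain carbon bound to an aromatic nitrogen gave a number 0.59 log units higher from compound 3 to compound 4 (beyond the scatter) on one core, while on the other core the same change gave a number 0.09 log units higher from compound 2 to compound 1 (within the scatter) and so could not be told apart from no step at all. This shows that the size of the step did not carry over between these two cores, so a step read on one core was a poor guide to the other, even though the change itself is described in the same words. It does not show which step is typical of either core, since each core offers only one pair, or whether other changes would also differ between the cores, and no measurement shown here explains the difference.

The compounds shown leave open whether a longer chain such as propyl, in place of the ethyl group of compound 4, would extend the step on this core. They also leave open whether a carboxylic acid at that place would give steps that agree or differ between the two cores.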